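Swapping a nitrophenyl for a styryl group on a pyrazoline

The compounds below may be only part of what the source reports. "The series", "measured", "known", "first", "only" and "open" are said of these compounds alone.

Of the compounds shown here, two from this series have been tested in a functional assay on IMR-32 cells (Homo sapiens) for cytotoxicity, read by sulforhodamine B assay, with a stated time of 48 h; a lower number here means a stronger inhibitor, a higher number a weaker inhibitor. Compound 1, `CC(=O)N1N=C(c2ccc(Br)cc2)CC1c1cccc(Cl)c1Cl`, gives 45700 nM in this assay. Compound 2, `O=CCN1N=C(c2ccc3ccccc3c2)CC1c1cccc([N+](=O)[O-])c1`, gives 3280 nM, the lower of the two numbers and therefore the stronger inhibitor of the pair, with compound 1 well outside the usual scatter above it.

Compound 3, `O=CCN1N=C(c2ccc3ccccc3c2)CC1/C=C/c1ccccc1`, has not yet been measured. It differs from compound 2 in one place: 2-phenylethenyl in place of 3-nitrophenyl on a saturated ring carbon. Going by the values given here, no pair of measured compounds shows the effect of this kind of swap, so the expectation rests on compound 2 alone. The step of a 1.5-fold higher number from compound 2 to compound 3 (0.18 log units; within the scatter) is estimated to be modest, not far beyond the scatter, with a slight lean toward a weaker compound. Compound 3 is therefore expected to give about 5000 nM in this assay, within a range of 1500 nM to 20000 nM.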

Compound 3, half-maximal inhibitory concentration: 17200 nM
For compound 3 the middle estimate is 3.4-fold (0.54 log units) below the measured one, and the stated range covers the measured number.
By their numbers in this assay, from the lowest: compound 2; then compound 3; then compound 1.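

Going by these compounds alone, this is the first one-place change measured. On the saturated ring carbon next to the ring nitrogen, in this assay, replacing 3-nitrophenyl with 2-phenylethenyl gives a 5.2-fold higher number from compound 2 to compound 3 (0.72 log units; beyond the scatter), so the stronger inhibitor of this pair is the one carrying 3-nitrophenyl, and this position is not indifferent to the group it holds. Both groups contain one six-membered aromatic ring of carbon only, and of the two only 3-nitrophenyl counts hydrogen-bond acceptors, but no measurement here explains why the number moved.

The compounds shown leave open which part of the 3-nitrophenyl group matters, a question that a plain phenyl or a 3-aminophenyl group at this carbon would help to settle. From the compounds shown here alone, whether the swap gives a similar step with a longer chain in place of formylmethyl also remains open.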